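A few compounds are considered here, and "the series" means these few. Any claim that something is new, unique, unknown or untested is made for them only; others in the source may bear on it.

Working notes on the series, measured in an ADME assay on BCBL1 cells (Homo sapiens) for cytotoxicity, with a stated time of 7 days; on this read-out lower numbers stand for higher toxicity in this test and higher numbers for lower toxicity in this test:

- compound 1 `Nc1nc(OCC(F)(F)F)c2ncn(/C=C3/CC3(CO)CO)c2n1`: > 20000 nM
- compound 2 `COCCOc1nc(N)nc2c1ncn2/C=C1/CC1(CO)CO`: > 20000 nM
- compound 3 `CCCSc1nc(N)nc2c1ncn2/C=C1/CC1(CO)CO`: > 20000 nM

Each entry is a limit of the assay and not a number. Compound 2 therefore has no readable value, only its limit of > 20000 nM. It shares that position with the other two compounds, as the evidence shows: the limit of > 20000 nM in this assay, at which 3 of the 3 values shown sit.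

The next structure is compound 4 `Nc1nc(NC2CC2)c2ncn(/C=C3/CC3(CO)CO)c2n1`. The change is cyclopropylamino in place of 2-methoxyethoxy on an aromatic carbon.

For the measured compounds named here, three measured steps bear on this. The closest are a step that the two limits leave unreadable from compound 2 to compound 3 and a step that the two limits leave unreadable from compound 1 to compound 3, both exchanges on the same aromatic carbon. The third, a step that the two limits leave unreadable from compound 1 to compound 2, alters only the chain of the group on that carbon. Going by the values given here, none of the three has a readable size, and no measured compound carries cyclopropylamino.

The expectation rests mainly on compound 3, whose different group still gives the limit > 20000 nM. The expected change is a number no higher from compound 2 to compound 4 (the limit leaves the size open), with no firm direction, and in this assay a further limit is the likeliest outcome. For compound 4 the estimated value is 20000 nM, with an expected range from 8000 nM to 50000 nM.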

Compound 4, half-maximal cytotoxic concentration: 71500 nM
Compound 4: middle estimate off by 3.6-fold (0.55 log units), on the low side, outside the stated range (above it).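

No step to compound 4 can be read from compound 1, compound 2 or compound 3, since each of those three stands only at a limit of the assay: the limit of > 20000 nM in this assay, at which 3 of the 4 values shown sit.

The compounds shown leave open how far cyclopropylamino differs in this assay from the other three groups on that aromatic carbon, and whether those three differ among themselves.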